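From ethoxycarbonyl to neopentyloxycarbonyl on the shared core

This account rests on a few compounds, and the source may have more. Where it says the series, first, only, none or still open, it means among the compounds named here.

Of the compounds shown here, two with the shared core have been measured in a physicochemical assay for solubility, in phosphate buffer, with a stated time of 18 h, at pH 7.4; on this read-out higher numbers stand for higher solubility and lower numbers for lower solubility. Compound 1 `COc1cc2ncnc(-n3nc(-c4ccccn4)nc3N)c2cc1OCCCN1CC(C)OC(C)C1`, which carries 2,6-dimethylmorpholin-4-yl on its chain, gives 8000 nM. Compound 2 `CCOC(=O)NCCCOc1cc2c(-n3nc(-c4ccccn4)nc3N)ncnc2cc1OC`, which carries (ethoxycarbonyl)amino there, gives 16000 nM. Going by the values given here, the one measured step, a 2.0-fold higher number from compound 1 to compound 2 (0.30 log units; within the scatter), does not separate them, so compound 2 stands level with compound 1 on these two numbers.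

Compound 3 `COc1cc2ncnc(-n3nc(-c4ccccn4)nc3N)c2cc1OCCCNC(=O)OCC(C)(C)C` differs from compound 2 in one place. The change is tert-butyl in place of methyl on a saturated chain carbon bound to an oxygen next to a carbonyl group, on a saturated chain carbon bound to an oxygen next to a carbonyl group, so ethoxycarbonyl becomes neopentyloxycarbonyl. Among the compounds with values here, no measured pair varies this group, and the step of a 2.0-fold higher number from compound 1 to compound 2 (0.30 log units; within the scatter) concerns a different change, so it is only a loose guide. A modest move to a lower number in this assay is nevertheless expected, with a wide margin of doubt. The expected step is a 2.7-fold lower number from compound 2 to compound 3 (0.43 log units; beyond the scatter). For compound 3 the estimated value is 6000 nM, with an expected range from 1500 nM to 16000 nM.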

Compound 3, solubility: 200 nM
Estimate against measurement, compound 3: 30-fold (1.48 log units) above, and the stated range ends above it.
By their numbers in this assay, from the lowest: compound 3; then compounds 1 and 2 (each within the scatter of the next).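

Putting tert-butyl in place of methyl on a saturated chain carbon bound to an oxygen next to a carbonyl group, which turns ethoxycarbonyl into neopentyloxycarbonyl, gives an 80-fold lower number from compound 2 to compound 3 (1.90 log units; beyond the scatter) in this assay. Going by these compounds alone, this shows that the read-out responds strongly to a change at this end of the chain, whereas the only earlier step, a different change, stayed within the scatter. Compound 3 also stands apart from the compound carrying 2,6-dimethylmorpholin-4-yl, with a 40-fold lower number from compound 1 to compound 3 (1.60 log units; beyond the scatter), so compound 3 now lies alone at the low end while compounds 1 and 2 remain level, and nothing among these data gives a reason for a drop of this size.

With only methyl and tert-butyl shown at this place, it stays open whether the fall follows the branching of tert-butyl or simply the added carbons. An isopropyl group or a straight butyl chain there, or an amine or a carboxylic acid at the end of the chain, would show how the read-out moves between these extremes.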